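A few compounds are considered here, and "the series" means these few. Any claim that something is new, unique, unknown or untested is made for them only; others in the source may bear on it.

Compound 1 `O=C(CI)NCCCNc1ncnc2c1ncn2[C@@H]1O[C@H](COP(=O)(O)OP(=O)(O)OP(=O)(O)O)[C@@H](O)[C@H]1O` was tested in an assay on isolated protein for inhibition of hexokinase-2 (Rattus norvegicus), with a stated time of 6 h, tested at 10 mM (on this read-out lower numbers stand for less inhibition and higher numbers for more inhibition at the one concentration tested (going by the name of the read-out)), where compound 1 gives 0%. Compound 2 `O=C(CI)NCCCCNc1ncnc2c1ncn2[C@@H]1O[C@H](COP(=O)(O)OP(=O)(O)OP(=O)(O)O)[C@@H](O)[C@H]1O` gives 0% and compound 3 `O=C(CI)NCCNc1ncnc2c1ncn2[C@@H]1O[C@H](COP(=O)(O)OP(=O)(O)OP(=O)(O)O)[C@@H](O)[C@H]1O` gives 0%, so compound 1 stands level with both within the scatter. Compound 4 `O=C(CI)NCCCCCCC(=O)NCCCNc1ncnc2c1ncn2[C@@H]1O[C@H](COP(=O)(O)OP(=O)(O)OP(=O)(O)O)[C@@H](O)[C@H]1O` differs from compound 1 as follows: 5-(((iodomethyl)carbonyl)amino)pentyl in place of iodo on a saturated chain carbon bound to a carbonyl carbon. For the measured compounds named here, no measured step alters this part of the molecule, so the only guidance comes from the three steps that alter the length of the saturated chain, which gave no change at the digits printed from compound 1 to compound 2 (within the scatter), no change at the digits printed from compound 1 to compound 3 (within the scatter) and no change at the digits printed from compound 2 to compound 3 (within the scatter). Those steps all stayed within the scatter, and a further lengthening is expected to do the same. Compound 4 is therefore expected to show a step of no change at the digits printed from compound 1 to compound 4 (within the scatter). The estimate for compound 4 is 0%, within 0% to 10%.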

Compound 4, a percentage reported as inhibition, at one concentration (the size of the read-out at that concentration, not a potency): 0%
Estimate against measurement, compound 4: no gap at the digits printed, within the range that was stated.
By their numbers in this assay, from the lowest: compounds 1, 2, 3 and 4 (each within the scatter of the next).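

In this assay, putting 5-(((iodomethyl)carbonyl)amino)pentyl in place of iodo on a saturated chain carbon bound to a carbonyl carbon gives no change at the digits printed from compound 1 to compound 4 (within the scatter). For the compounds shown here, this is the first reading at this position, and even this much larger group leaves the read-out level with the shorter chains of the earlier compounds. No evidence is available to explain this result. As far as these compounds go, all four compounds read alike, so it remains open whether an amine or a carboxylic acid at this position would give any inhibition.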